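Methyl on the acid chain of compound 3

The source may hold more compounds than are shown below. What is called first, only, known or untested is meant among the compounds shown, and "the series" means these compounds.

Among the compounds with values here, in an ADME assay on cells (Hepatocyte, Mus musculus) for metabolic stability, read by LC-MS, with a stated time of 180 min, tested at 1 uM (on this read-out lower numbers stand for slow clearance and higher numbers for fast clearance), compound 3 `CC(C(=O)O)c1nn(Cc2cn3cc(OCC4CC4)c(Cl)cc3n2)c2ccccc2c1=O` gives 76.7 mL/min/kg as the only actual number. Compound 1 `O=C(O)Cn1nc(Cc2nc3cc(Cl)c(OCC(F)F)cc3[nH]2)c2ccccc2c1=O` reports < 28.4 mL/min/kg as a limit of the assay and not a number. Compound 2 `O=C(O)Cn1nc(Cc2nc3cc(Cl)c(OC(F)(F)F)cc3[nH]2)c2ccccc2c1=O` likewise reports < 38.4 mL/min/kg as a limit of the assay and not a number.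

The change to compound 4 `CC(C)(C(=O)O)c1nn(Cc2cn3cc(OCC4CC4)c(Cl)cc3n2)c2ccccc2c1=O` is methyl in place of hydrogen on a saturated chain carbon bound to an aromatic carbon, a carbonyl carbon and a saturated chain carbon and turns 1-carboxyethyl into 1-carboxy-1-methylethyl. Within the data shown here, the one measured step that the two limits leave unreadable from compound 1 to compound 2 concerns a different change and has no readable size, so it sets no size or direction for this one. With compound 3 at 76.7 mL/min/kg as the sole anchor, this assay is expected to show no step beyond the usual scatter and no clear direction. The estimated 1.2-fold lower number from compound 3 to compound 4 (0.07 log units; within the scatter) therefore stays within that scatter. Compound 4 is estimated at 65 mL/min/kg with an expected range of 32 mL/min/kg to 125 mL/min/kg on this read-out.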

Compound 4, clearance: 317 mL/min/kg
The estimate for compound 4 lay 4.9-fold (0.69 log units) below the measured number; measured number above the stated range.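

In this assay, within the data shown here, the saturated chain carbon bound to an aromatic carbon, a carbonyl carbon and a saturated chain carbon is the first place with a readable step: methyl in place of hydrogen gives a 4.1-fold higher number from compound 3 to compound 4 (0.62 log units; beyond the scatter) and so moves the read-out towards faster clearance. The other step in the series cannot be read, so this pair alone carries the information on size and direction. No evidence at hand bears on why this change has this effect.

The compounds shown leave open where an ethyl in place of the added methyl, or a cyclopropane ring joining the two methyls of 1-carboxy-1-methylethyl, would fall relative to compound 3 and compound 4. They also leave open whether the same methyl would give a step of similar size and direction on the core of compound 1.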